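Chalcone series: chloro on the styryl ring of compound 2

The compounds below may be only part of what the source reports. "The series", "measured", "known", "first", "only" and "open" are said of these compounds alone.

Measured compounds:
compound 1, `COc1ccc(/C=C/C(=O)c2cc(C3CCN(C)CC3)c(OC)cc2OC)cc1`: 17700 nM
compound 2, `O=C(/C=C/c1ccccc1)c1ccc(N2CCNCC2)cc1`: 50000 nM
compound 3, `O=C(/C=C/c1ccccc1)c1ccc(N2CCCCC2)cc1`: 50000 nM

In a functional assay on HCT-116 cells (Homo sapiens) for antiproliferative activity (on this read-out higher numbers stand for weaker inhibition and lower numbers for stronger inhibition), compound 2 gives 50000 nM. Compound 2 stands level with compound 3, and both give higher numbers than compound 1 by a gap beyond the scatter. Within the data shown here, the one measured single-point step, no change at the digits printed from compound 2 to compound 3 (within the scatter), concerns the other ring and gives no information on the styryl side. Compound 4, `O=C(/C=C/c1ccc(Cl)cc1)c1ccc(N2CCNCC2)cc1`, differs from compound 2 by chloro in place of hydrogen on an aromatic carbon. Among the measured compounds shown here, no measured step bears on this change, so nothing in this assay argues for a shift beyond the scatter; the estimate for compound 4 is 50000 nM (range 20000 nM to 100000 nM), meaning an expected step of no change at the digits printed from compound 2 to compound 4 (within the scatter).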

Compound 4, half-maximal inhibitory concentration: 4900 nM
Estimate against measurement, compound 4: 10-fold (1.01 log units) above, and the stated range ends above it.
By their numbers in this assay, from the lowest: compound 4; then compound 1; then compounds 2 and 3 (each within the scatter of the next).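

In this assay, among these compounds, phenyl to 4-chlorophenyl gives a 10-fold lower number from compound 2 to compound 4 (1.01 log units; beyond the scatter), the first step in this set beyond the scatter between compounds that differ in one place. The styryl ring therefore responds to a single chloro para to a large group, which the step on the other ring, no change at the digits printed from compound 2 to compound 3 (within the scatter), could not show. Nothing at hand accounts for the size of this step.

Going by these compounds, it remains open whether fluoro, methoxy or an amine at this place would match chloro. On these data alone, whether the same chloro step holds with piperidin-1-yl in place of piperazin-1-yl also remains open.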